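The source may report more compounds than this note shows. Statements on the series, on what has been measured and on what is new or still open speak of the compounds shown alone.

Measured in an ADME assay on HEK293 cells (Homo sapiens) for cytotoxicity, with a stated time of 72 h; a higher number here means that more compound is needed for the effect, a lower number that less compound is needed
- Compound 1 `C=C[C@@](C)(/C=C/c1ccc(OC)cc1)CCC=C(C)C` gives > 36600 nM
- Compound 2 `C=C[C@@](C)(/C=C/c1ccc(O)cc1)CCC1OC1(C)C` gives > 36600 nM

Compound 2 has no exact number, only a limit of the assay (> 36600 nM). Compound 1 stands at the same kind of limit, so the two share the limit of > 36600 nM in this assay, at which 2 of the 2 values shown sit, and show no graded response. Compound 3 `C=C[C@@](C)(/C=C/c1ccc(O)cc1)CC/C=C(\C)C=O` differs from compound 2 by 2-formylprop-1-en-1-yl in place of 3,3-dimethyloxiran-2-yl on a saturated chain carbon, three bonds along the chain from two double-bonded chain carbons, with 2-formylprop-1-en-1-yl in place of 3,3-dimethyloxiran-2-yl. Among the compounds with values here, no measured step gauges this change in this assay, so no shift beyond the scatter is expected. The expected a number no higher from compound 2 to compound 3 (the limit leaves the size open) is therefore small, and another limit is likely. Compound 3 is estimated at 36600 nM, within a range of 15000 nM to 80000 nM.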

Compound 3, half-maximal effective concentration: > 36600 nM
Compound 3 was reported as a limit; the forecaster's own chance of this, stated with the estimate: 70%; the middle value sits exactly at the limit.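

In this assay compound 2 and compound 3 are both reported only as limits, so no step can be read between them. The compounds shown leave open how far any of them lies from that limit, and whether this change of side chain shifts the read-out at all.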